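Replacing an amino group of compound 1 with hydrogen

A few compounds are considered here, and "the series" means these few. Any claim that something is new, unique, unknown or untested is made for them only; others in the source may bear on it.

Compound 1 `C=C1[C@H](n2cnc3c(N)nc(N)nc32)O[C@H](CO)[C@H]1O`: > 500000 nM (a limit)
Compound 2 `C=C1[C@H](n2cnc3c(S)nc(N)nc32)O[C@H](CO)[C@H]1O`: 480 nM

In a functional assay on MT4 cells (Homo sapiens) for inhibition (a lower number here means a stronger inhibitor, a higher number a weaker inhibitor), compound 1 has no number, only a limit, > 500000 nM. Compound 3 `C=C1[C@H](n2cnc3c(N)ncnc32)O[C@H](CO)[C@H]1O` is the next to be measured, and it differs from compound 1 by hydrogen in place of amino on an aromatic carbon, with hydrogen in place of amino on an aromatic carbon. Among the compounds with values here, only one measured step bears on this. It is large, an at least 1000-fold lower number from compound 1 to compound 2 (3.01 log units; beyond the scatter), and it has sulfanyl in place of amino on an aromatic carbon. That step involves a different amino group, and no sulfanyl enters compound 3, so the gain seen in compound 2 at 480 nM is not expected to carry over. Only a small change is expected, an at least 1.6-fold lower number from compound 1 to compound 3 (0.22 log units; that floor lies within the scatter), and compound 3 may also reach the limit. Compound 3 is estimated at 300000 nM, with an expected range of 30000 nM to 1000000 nM.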

Compound 3, half-maximal inhibitory concentration: 131000 nM
Beside the measured number, compound 3's estimate is 2.3-fold (0.36 log units) above it; low and high end bracket the measured number.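

In this assay, hydrogen in place of amino on an aromatic carbon between two ring nitrogen atoms gives an at least 3.8-fold lower number from compound 1 to compound 3 (0.58 log units; beyond the scatter), so this position also affects inhibition, and the amino group there is not required for the activity measured in compound 3. Compound 1 stands at > 500000 nM, which is a limit and not a number. The true size of the step therefore remains unknown and only its floor can be read, because compound 1 sits at that limit: the limit of > 500000 nM in this assay, at which 1 of the 3 values shown sits.

The compounds shown leave open how a methyl group, a chlorine atom or a methylamino group at this position would compare with hydrogen. They also leave open how hydrogen here would combine with sulfanyl on the other aromatic carbon, the change seen in compound 2.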